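Swapping bromo for chloro on the fused core

A few compounds are considered here, and "the series" means these few. Any claim that something is new, unique, unknown or untested is made for them only; others in the source may bear on it.

Measured compounds: compound 1 `Clc1ccc(Cn2nnc3c(Br)cccc32)cc1` with 2 mL/min/g, compound 2 `Brc1ccc(Cn2nnc3c(Br)cccc32)cc1` with 2.6 mL/min/g, compound 3 `Brc1cccc2c1nnn2CC1CC1` with 7.7 mL/min/g, all in an ADME assay on microsomes from liver (Mus musculus, strain NMRI) for metabolic stability, tested at 2.5 uM; a lower number here means slower removal, a higher number faster removal of the compound.

Compound 4 `Clc1cccc2c1nnn2CC1CC1` is not yet measured. The change from compound 3 to compound 4 is chloro in place of bromo on an aromatic carbon. The same kind of change has been made once before, from compound 2 to compound 1, as chloro in place of bromo on an aromatic carbon, where it gave a 1.3-fold lower number from compound 2 to compound 1 (0.11 log units; within the scatter). The surroundings differ: in compound 1 the halogen sits para to a large group, whereas in compound 4 it sits on a ring that is part of a fused or bridged system of two rings, ortho and meta to a fused ring. The difference between the two cores of compound 2 and compound 3 is not broken down here. Compound 3 shows the highest number of the three in this assay.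

Resting on the earlier step, the expected step from compound 3 to compound 4 is a 1.2-fold lower number from compound 3 to compound 4 (0.07 log units; within the scatter). Compound 4 is therefore estimated at 6.5 mL/min/g, between 3.5 mL/min/g and 12 mL/min/g.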

Compound 4, intrinsic clearance in a liver preparation (reported as CLH), per the amount of preparation that the assay uses: 5.7 mL/min/g
Compound 4: the middle estimate sits 1.1-fold (0.06 log units) above what was measured; low and high end bracket the measured number.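

In this assay, chloro in place of bromo on an aromatic carbon gave a 1.4-fold lower number from compound 3 to compound 4 (0.13 log units; within the scatter). Set beside the earlier case, the change carried over from one core to the other with no visible difference: the same change on two cores in this assay, a 1.3-fold lower number (0.11 log units; within the scatter) from compound 2 to compound 1 and a 1.4-fold lower number (0.13 log units; within the scatter) from compound 3 to compound 4, 1.0-fold (0.02 log units) apart, within the scatter of two such steps. Among the compounds shown here, both steps lie within the scatter, so the pair shows only that the swap left the number little moved on these two cores; it shows no real gain from chloro and, resting on two cores, no general rule.

The compounds shown carry only bromo or chloro at the places changed, so what fluoro, a nitrile or a methoxy group would do there stays open. Also open, on these data alone, is whether the swap behaves alike on a core bearing an amine or a carboxylic acid.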